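The source may hold more compounds than are shown below. What is called first, only, known or untested is meant among the compounds shown, and "the series" means these compounds.

Measured in a functional assay on BEAS-2B cells (Homo sapiens) for inhibition, read by MTT assay, with a stated time of 72 h; on this read-out lower numbers stand for stronger inhibition and higher numbers for weaker inhibition:

compound 1, `C=C(c1ccc(F)c(F)c1)C1COC(C)(C)OO1`: > 100000 nM, which is a limit of the assay and not a number
compound 2, `C=C(c1ccc(OC)c(F)c1)C1COC(C)(C)OO1`: 68700 nM
compound 3, `C=C(c1ccc(F)c(F)c1)C1COC2(CCCCC2)OO1`: 61200 nM

Compound 1 sits at the limit of > 100000 nM in this assay, at which 1 of the 3 values shown sits. Among the measured compounds shown here, the one change from compound 1 to compound 2 is methoxy in place of fluoro on an aromatic carbon, and it produced an at least 1.4-fold lower number from compound 1 to compound 2 (0.16 log units; that floor lies within the scatter); as that step starts from a limit, only its floor is known. Compound 2 and compound 3 lie within the scatter of each other, so no order between them is read. The core of compound 3 differs from the core of compound 1, but that difference is not broken down here.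

Compound 4, `C=C(c1ccc(OC)c(F)c1)C1COC2(CCCCC2)OO1`, has not yet been measured in this assay. It stands to compound 3 as compound 2 stands to compound 1: methoxy in place of fluoro on an aromatic carbon, the same kind of change at the same kind of place. On the strength of an at least 1.4-fold lower number from compound 1 to compound 2 (0.16 log units; that floor lies within the scatter), the step from compound 3 to compound 4 is expected to be a 1.5-fold lower number from compound 3 to compound 4 (0.18 log units; within the scatter), a modest lowering of the number rather than a large one. Compound 4 is therefore estimated at 40000 nM, with a likely span from 15000 nM to 100000 nM.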

Compound 4, half-maximal inhibitory concentration: 37700 nM
Beside the measured number, compound 4's estimate is 1.1-fold (0.03 log units) above it, and the stated range covers the measured number.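

In this assay, methoxy in place of fluoro on an aromatic carbon gives a 1.6-fold lower number from compound 3 to compound 4 (0.21 log units; within the scatter), so this step on its own does not establish a real change in the number. Compound 1 carries a limit of the assay and not a number (> 100000 nM). Both steps point the same way, which is consistent with the change carrying from one core to the other, but this does not show that it does so, and it gives no sizes that can be set against each other: the same change on two cores in this assay, an at least 1.4-fold lower number (0.16 log units; that floor lies within the scatter) from compound 1 to compound 2 and a 1.6-fold lower number (0.21 log units; within the scatter) from compound 3 to compound 4; the limit leaves it open whether they differ

The compounds shown leave open how other groups on this aromatic carbon would read, such as an amine, a hydroxy group or a longer alkoxy chain. They also leave open whether the same change would carry to cores beyond these two, for example a core bearing a carboxylic acid or a longer chain.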